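The source may report more compounds than this note shows. Statements on the series, on what has been measured and on what is new or still open speak of the compounds shown alone.

Compound 2 `CCCC(=O)C1=C(C)NC(=O)NC1c1ccsc1` gives 1% in an assay on membranes from HeLa cells for displacement of a labelled ligand from adenosine receptor A3 (Homo sapiens), read by scintillation counting, with a stated time of 180 min, tested at 1 uM; a higher number here means more inhibition at the concentration tested (going by the name of the read-out), a lower number less inhibition; compound 1 `CCCC(=O)C1=C(C)NC(=O)NC1c1ccoc1` gives 2% in this assay, and the step of a number 1 percentage points lower from compound 1 to compound 2 (within the scatter) lies within the scatter, so the two numbers cannot be ordered. Compound 3 `CCC(CC)OC(=O)C1=C(C)NC(=O)NC1c1ccsc1` differs from compound 2 by (pentan-3-yl)oxy in place of propyl on a carbonyl carbon. Within the data shown here, no measured step touches the carbonyl carbon; the only known step concerns the ring on the saturated ring carbon, so nothing measured bears on this change. The expected step is therefore none beyond the scatter, a number 1 percentage points higher from compound 2 to compound 3 (within the scatter). For compound 3 the estimate in this assay is 2%, with a range from -8% to 12%.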

Compound 3, a percentage reported as inhibition, at one concentration (the size of the read-out at that concentration, not a potency): 6%
The estimate for compound 3 lay 4 percentage points below the measured number; measured number inside the range.
By their numbers in this assay, from the lowest: compounds 2, 1 and 3 (each within the scatter of the next).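

On the carbonyl carbon, (pentan-3-yl)oxy in place of propyl gives a number 5 percentage points higher from compound 2 to compound 3 (within the scatter) in this assay, so the one change shown at this position does not separate the two compounds. Replacing the propyl with this larger group, which adds a hydrogen-bond acceptor, therefore leaves the read-out indistinguishable from that of compound 2. Nothing on hand offers an explanation for this result.

As far as these compounds go, whether an amine or a carboxylic acid on the carbonyl carbon would move the number beyond the scatter stays open. So does the effect of a longer chain there.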